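Swapping bromo for isopropyl on a cinnamamide series

A few compounds are considered here, and "the series" means these few. Any claim that something is new, unique, unknown or untested is made for them only; others in the source may bear on it.

Of the compounds shown here, two of a shared core have been measured in a functional assay on HEK293 cells for activation of melanin-concentrating hormone receptor 1 (Homo sapiens), read by inositol phosphate accumulation; a higher number here means that more compound is needed for the effect, a lower number that less compound is needed. Compound 1, `CCCc1cc(N)c2cc(NC(=O)/C=C/c3ccc(CC)cc3)ccc2n1`, carries an ethyl group on the outer ring and gives 160 nM. Compound 2, `CCCc1cc(N)c2cc(NC(=O)/C=C/c3ccc(Br)cc3)ccc2n1`, carries bromo at the same place and gives 93 nM. Of the two numbers, compound 2 has the lower one, but the change a 1.7-fold lower number from compound 1 to compound 2 (0.24 log units; within the scatter) is within the usual scatter, so no order between the two can be claimed.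

Compound 3, `CCCc1cc(N)c2cc(NC(=O)/C=C/c3ccc(C(C)C)cc3)ccc2n1`, has not yet been measured. It differs from compound 2 by isopropyl in place of bromo on an aromatic carbon. Among the measured compounds shown here, the only measured step that bears on it is the exchange of ethyl for bromo, which moved the number by a 1.7-fold lower number from compound 1 to compound 2 (0.24 log units; within the scatter). Isopropyl is a carbon group much like ethyl, so the reverse move is expected to land near the value of compound 1, and the step of a 1.6-fold higher number from compound 2 to compound 3 (0.21 log units; within the scatter) is estimated to stay within the scatter. In this assay compound 3 is therefore expected to give about 150 nM, with a likely range from 60 nM to 400 nM.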

Compound 3, half-maximal effective concentration: 520 nM
For compound 3 the middle estimate is 3.5-fold (0.54 log units) below the measured one; measured number outside the range, above it.
By their numbers in this assay, from the lowest: compounds 2 and 1 (each within the scatter of the next); then compound 3.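

In this assay the group on this aromatic carbon, para to a large group, had not yet moved the number beyond the scatter, but a 5.6-fold higher number from compound 2 to compound 3 (0.75 log units; beyond the scatter) shows that the choice of group here can matter. The comparison between the two carbon groups is more telling: the single added methyl that turns ethyl into isopropyl gives a 3.3-fold higher number from compound 1 to compound 3 (0.51 log units; beyond the scatter) even though ethyl and bromo stay within the scatter of each other, so a carbon group cannot be treated as a stand-in for a close relative at this position. Nothing measured here says why the number rises with this change.

The three compounds cannot separate the effect of branching in the chain from that of simply adding one more carbon, and a straight propyl chain or a tert-butyl group at the same place would bear on that question. Also open, from the compounds shown here alone, is how groups of a different kind, such as chloro, methoxy, an amine or a carboxylic acid, would behave here, and whether the same order would hold on another core.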